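A few compounds are considered here, and "the series" means these few. Any claim that something is new, unique, unknown or untested is made for them only; others in the source may bear on it.

In a functional assay on cells (Splenocyte, Mus musculus, strain BALB/c) for inhibition, read by scintillation counting and thymidine incorporation, with stated times of 48 h and 8 h (on this read-out lower numbers stand for stronger inhibition and higher numbers for weaker inhibition), compound 1 `COc1cccc(-c2nc(Cc3c[nH]c4ccccc34)no2)c1` gives 11100 nM. Compound 2 `COc1cc(-c2noc(-c3ccccc3)n2)cc(OC)c1OC` carries an unsubstituted phenyl on a related core, and in this assay compound 2 reports only a limit of > 50000 nM, so no number is known for it. Compound 3 `COc1cc(-c2noc(-c3ccc(NC(=O)OC(C)(C)C)cc3)n2)cc(OC)c1OC` puts (tert-butoxycarbonyl)amino in place of hydrogen on an aromatic carbon of that phenyl and gives 2200 nM in this assay, which is an at least 22-fold lower number from compound 2 to compound 3 (1.35 log units; beyond the scatter). Only a lower bound of that step is known because compound 2 sits at the limit of > 50000 nM in this assay, at which 1 of the 3 values shown sits. Compound 4 `COc1cc(-c2noc(-c3cccc(N)c3)n2)cc(OC)c1OC` differs from compound 2 by amino in place of hydrogen on an aromatic carbon. For the measured compounds named here, the entering group is a different one from that in compound 3, so the step to compound 3 is the only guide and an imperfect one. A drop in the number is expected for compound 4, though a smaller one than was seen with compound 3, so that the expected step is an at least 3.3-fold lower number from compound 2 to compound 4 (0.52 log units; beyond the scatter). In this assay compound 4 is estimated at 15000 nM, with a likely range from 3000 nM to 50000 nM.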

Compound 4, half-maximal inhibitory concentration: 5500 nM
Beside the measured number, compound 4's estimate is 2.7-fold (0.44 log units) above it; measured number inside the range.
By their numbers in this assay, from the lowest: compound 3; then compounds 4 and 1 (each within the scatter of the next). At a limit, above all of these: compound 2.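

The result shows that a group as small as amino, on an aromatic carbon meta to a large group, is enough to give an at least 9.0-fold lower number from compound 2 to compound 4 (0.95 log units; beyond the scatter) in this assay. Until now, the only gain on this phenyl had come from the much larger (tert-butoxycarbonyl)amino of compound 3, so the larger group is not needed for compound 4 to give a measurable number. The true size of the step from phenyl to 3-aminophenyl remains unknown, and only a lower bound can be read: the limit of > 50000 nM in this assay, at which 1 of the 4 values shown sits.

On these data alone, it remains open how much of the gain comes from the amino group itself and how much from its place on the ring. As far as these compounds go, it is also open whether a hydroxyl group, a carboxylic acid or a longer amine chain at this position would give a similar step.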